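Rearranging the Butyl Substituent on the Benzyl Group

A few compounds are considered here, and "the series" means these few. Any claim that something is new, unique, unknown or untested is made for them only; others in the source may bear on it.

Measured so far in an assay on Prostate gland for inhibition of steroid 5-alpha-reductase (Rattus norvegicus); on this read-out higher numbers stand for weaker inhibition and lower numbers for stronger inhibition:
Compound 1 `CCCC(C(C)C)n1ccc2cc(/C(C)=C/C(=O)Nc3ccccc3OCCCC(=O)O)ccc21` gives 7.2 nM.
Compound 2 `CCCCC(C)n1ccc2cc(/C(C)=C/C(=O)Nc3ccccc3OCCCC(=O)O)ccc21` gives 6 nM.
Compound 3 `CCCCc1ccc(Cn2ccc3cc(/C(C)=C/C(=O)Nc4ccccc4OCCCC(=O)O)ccc32)cc1` gives 100 nM.

Compound 3 has the highest number of the three. The steps of a 14-fold higher number from compound 1 to compound 3 (1.14 log units; beyond the scatter) and a 17-fold higher number from compound 2 to compound 3 (1.22 log units; beyond the scatter) both lie beyond the scatter, whereas a 1.2-fold lower number from compound 1 to compound 2 (0.08 log units; within the scatter) lies within it. Compound 4 `C/C(=C\C(=O)Nc1ccccc1OCCCC(=O)O)c1ccc2c(ccn2Cc2ccc(C(C)(C)C)cc2)c1` differs from compound 3 by tert-butyl in place of butyl on an aromatic carbon. Going by the values given here, no measured step touches this part of the molecule: all three measured changes sit on the aromatic nitrogen, and compound 3 is the only one carrying the 4-butylbenzyl group. With nothing to set a direction, the expected step is no change at the digits printed from compound 3 to compound 4 (within the scatter), not beyond the scatter. The estimate for compound 4 is 100 nM, with a range from 40 nM to 250 nM.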

Compound 4, half-maximal inhibitory concentration: 170 nM
Estimate against measurement, compound 4: 1.7-fold (0.23 log units) below; measured number inside the range.
By their numbers in this assay, from the lowest: compounds 2 and 1 (each within the scatter of the next); then compounds 3 and 4 (each within the scatter of the next).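

In this assay the change from butyl to tert-butyl gives a 1.7-fold higher number from compound 3 to compound 4 (0.23 log units; within the scatter) and so shows that this position accepts either arrangement of the four carbons. Rearranging the butyl substituent does not close the gap to the compounds with alkyl groups on the aromatic nitrogen, with a 28-fold higher number from compound 2 to compound 4 (1.45 log units; beyond the scatter) and a 24-fold higher number from compound 1 to compound 4 (1.37 log units; beyond the scatter) still standing. No available evidence accounts for these numbers. Still open, going by these compounds, is whether a methoxy group, a chlorine atom or a longer chain at this place would shift the number, and where an unsubstituted benzyl group would fall.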